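A Dimethoxybenzyl Variant of a Weak Sulfonamide Inhibitor

The source may report more compounds than this note shows. Statements on the series, on what has been measured and on what is new or still open speak of the compounds shown alone.

compound 1 `O=S(=O)(NCCCNCc1ccccc1Cl)c1cc(C(F)(F)F)cc(C(F)(F)F)c1`: 20000 nM
compound 2 `O=S(=O)(NCCNCc1ccc(-c2ccccc2)cc1)c1cc(C(F)(F)F)cc(C(F)(F)F)c1`: 2700 nM
compound 3 `O=S(=O)(NCCCCNCc1ccc(Br)cc1)c1cc(C(F)(F)F)cc(C(F)(F)F)c1`: 1600 nM

In a functional assay on HT-29 cells (Homo sapiens) for inhibition, read by MTT assay, with a stated time of 72 h (a higher number here means a weaker inhibitor of growth, a lower number a stronger inhibitor of growth), compound 1 stands highest of the three numbers, with compound 2 nearest and compound 3 furthest from it. Compound 4 `COc1ccc(CNCCCNS(=O)(=O)c2cc(C(F)(F)F)cc(C(F)(F)F)c2)cc1OC` differs from compound 1 by 3,4-dimethoxyphenyl in place of 2-chlorophenyl on a saturated chain carbon bound to an amine nitrogen. Going by the values given here, only one measured step bears on this change: a 13-fold lower number from compound 1 to compound 3 (1.10 log units; beyond the scatter), and that step is not a pure swap of the aryl group, as the place on the chain differs too. Among the compounds with values here, the 3,4-dimethoxyphenyl group itself has no precedent among the measured compounds. For compound 4 a modest move toward lower numbers is expected, a 2.5-fold lower number from compound 1 to compound 4 (0.40 log units; beyond the scatter). Compound 4 is therefore estimated at 8000 nM, with a range from 2500 nM to 25000 nM.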

Compound 4, concentration for 50% growth inhibition: 2700 nM
Compound 4: middle estimate off by 3.0-fold (0.47 log units), on the high side, within the range that was stated.
By their numbers in this assay, from the lowest: compounds 3, 2 and 4 (each within the scatter of the next); then compound 1.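

Going by these compounds alone, with the aryl group as the only change, a 7.4-fold lower number from compound 1 to compound 4 (0.87 log units; beyond the scatter) in this assay gives the first clean reading at this position, since the earlier large step also altered the chain. It shows that on a saturated chain carbon bound to an amine nitrogen, 3,4-dimethoxyphenyl in place of 2-chlorophenyl is enough to lower the number beyond the scatter. Nothing measured here explains this shift.

Going by these compounds, it remains open whether removing the chlorine or adding the methoxy groups accounts for the shift, and whether a single methoxy group, as in 4-methoxyphenyl, would do the same. Also open, on these data alone, is how 3,4-dimethoxyphenyl behaves on a longer chain.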